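The source may hold more compounds than are shown below. What is called first, only, known or untested is meant among the compounds shown, and "the series" means these compounds.

Working notes on the coumarin-pyrazole imine series in a functional assay on SMMC-7721 cells (Homo sapiens) for antiproliferative activity, read by MTT assay, with a stated time of 72 h; a higher number here means a weaker inhibitor, a lower number a stronger inhibitor.

Compound 1 `Cc1nn(C)c(Oc2ccc(Br)cc2)c1/C=N\CCCCCOc1cc2oc(=O)cc(C)c2cc1Cl` carries the bromophenoxy variant; in this assay compound 1 gives "not determined" (no result reported). Compound 2 `Cc1nn(C)c(Oc2ccc(I)cc2)c1/C=N\CCCCCOc1cc2oc(=O)cc(C)c2cc1Cl` is the iodophenoxy analogue. Compound 2 gives only a limit in this assay, > 25000 nM, not a number. Compound 3 `Cc1nn(C)c(Oc2ccc(F)cc2F)c1/C=N\CCCCCCOc1cc2oc(=O)cc(C)c2cc1Cl` bears the 2,4-difluorophenyl group on the aromatic oxygen. Compound 3 likewise gives only a limit in this assay, > 25000 nM, so no number stands for it. Compound 3 therefore cannot be placed on a scale against the others: of the three entries shown, two sit at the limit of > 25000 nM in this assay, at which 2 of the 3 values shown sit, and one carries no result at all, and no measured step between any two compounds of the series is available.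

Compound 4 `Cc1nn(C)c(Oc2cccc(C(F)(F)F)c2)c1/C=N\CCCCCCOc1cc2oc(=O)cc(C)c2cc1Cl` is the next member to be measured. Relative to compound 3 the change is 3-(trifluoromethyl)phenyl in place of 2,4-difluorophenyl on an oxygen on an aromatic ring.

For the measured compounds named here, with no measured step and both recorded entries sitting at the assay limit, no direction can be read from the data for this change in this assay. The working expectation is that compound 4 will also return a limit rather than a number. The step from compound 3 to compound 4 is estimated at a step that the limit leaves unreadable from compound 3 to compound 4, that is, nothing beyond the scatter. Compound 4 is estimated at 30000 nM, in the range 15000 nM to 60000 nM.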

Compound 4, half-maximal inhibitory concentration: 24800 nM
The estimate for compound 4 lay 1.2-fold (0.08 log units) above the measured number; the measured number falls inside the stated range.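

For the compounds shown here, compound 4 is the first entry to give a number rather than a limit in this assay, which shows that this position, on an oxygen on an aromatic ring, can yield a readable value. Placing 3-(trifluoromethyl)phenyl where 2,4-difluorophenyl stood gives a number no higher from compound 3 to compound 4 (the limit leaves the size open), so this change has a direction but no size that can be stated. The set as a whole still offers little to compare, and a single number gives no trend across the series: the limit of > 25000 nM in this assay, at which 2 of the 4 values shown sit.

It remains open whether the step from 2,4-difluorophenyl to 3-(trifluoromethyl)phenyl depends on the trifluoromethyl group itself or on where it sits on the ring, since the compounds shown include no other trifluoromethyl-bearing aryl group for a one-place comparison. Also open, from the compounds shown here alone, is how a phenyl group carrying an amine or a carboxylic acid at this position, or a longer chain between the imine and the core, would read in this assay, and whether either would give a value clearly apart from the rest of the series.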